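Swapping Fluorine for Chlorine in Bromoacyl Acylureas

This account rests on a few compounds, and the source may have more. Where it says the series, first, only, none or still open, it means among the compounds named here.

Compound 1, `CC(Br)C(=O)Nc1cc(C(=O)NC(N)=O)ccc1F`: 3130 nM
Compound 2, `CC(Br)C(=O)Nc1cc(C(=O)NC(N)=O)ccc1Cl`: 9800 nM
Compound 3, `NC(=O)NC(=O)c1cc(NC(=O)CBr)ccc1F`: < 10 nM

All three were tested in a functional assay on CCRF-CEM cells (Homo sapiens) for antiproliferative activity, read by trypan blue exclusion, with a stated time of 72 h; on this read-out higher numbers stand for weaker inhibition and lower numbers for stronger inhibition. Compound 1 gives 3130 nM in this assay. Compound 2 gives 9800 nM. For compound 3 the assay reports only a limit, < 10 nM, and not a number. The difference between the core of compound 1 and the core of compound 3 is not broken down here.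

Compound 2 differs from compound 1 by chloro in place of fluoro on an aromatic carbon. This single change gave a 3.1-fold higher number from compound 1 to compound 2 (0.50 log units; beyond the scatter).

Compound 4, `NC(=O)NC(=O)c1cc(NC(=O)CBr)ccc1Cl`, has not yet been measured. It differs from compound 3 by chloro in place of fluoro on an aromatic carbon. Within the data shown here, this is the same kind of change as the one from compound 1 to compound 2, but not the same: in the first pair the aromatic carbon is ortho to a ((1-bromoethyl)carbonyl)amino group and para to a carbamoylcarbamoyl group, while in the second it is ortho to a carbamoylcarbamoyl group and para to a ((bromomethyl)carbonyl)amino group.

The expectation is that compound 4 will show a step like a 3.1-fold higher number from compound 1 to compound 2 (0.50 log units; beyond the scatter), so compound 4 is estimated at 20 nM, with a likely range from 5 nM to 80 nM. The expected step is an at least 2.0-fold higher number from compound 3 to compound 4 (0.30 log units; that floor lies within the scatter), resting on the earlier pair. Because compound 3 sits at the limit of < 10 nM in this assay, at which 1 of the 3 values shown sits, there is a fair chance that compound 4 is also reported only as a limit.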

Compound 4, half-maximal inhibitory concentration: 540 nM
Compound 4: middle estimate off by 27-fold (1.43 log units), on the low side; the whole stated range lies below it.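

In this assay, chloro in place of fluoro gave an at least 54-fold higher number from compound 3 to compound 4 (1.73 log units; beyond the scatter), so the number rose on both cores, but the size of the step did not carry over from one core to the other: the same change on two cores in this assay, a 3.1-fold higher number (0.50 log units; beyond the scatter) from compound 1 to compound 2 and an at least 54-fold higher number (1.73 log units; beyond the scatter) from compound 3 to compound 4, at least 17-fold (1.23 log units) apart, beyond the scatter of two such steps

Compound 3 stands at < 10 nM, which is a limit of the assay and not a number. The size of this newer step is therefore only a floor, and two pairs cannot show why the swap counts for so much more on one core than on the other, since the differences between the two cores are not taken apart one at a time here.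

The compounds shown leave open how a plain hydrogen, a methyl group or a methoxy group on the same aromatic carbon would compare with fluoro and chloro on either core, which would show whether chloro stands out or fluoro does. They also leave open what would happen if the bromine of the ((bromomethyl)carbonyl)amino group gave way to chlorine, or if an amine or a longer chain took the place of that bromomethyl end.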